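A few compounds are considered here, and "the series" means these few. Any claim that something is new, unique, unknown or untested is made for them only; others in the source may bear on it.

The shared core of compound 1 `CCCCCCOc1ccc(-n2cnnc2CCCCC)cc1` carries a pentyl group on the aromatic carbon that lies between two ring nitrogen atoms, and in a functional assay on the whole organism (strain C57B/6) with Mus musculus as the target, in the maximal electroshock model (on this read-out lower numbers stand for an effect already at smaller amounts and higher numbers for an effect only at larger amounts of compound), compound 1 gives 32.8 mg/kg. For the measured compounds named here, that is the only number among the three values shown, because the limit of > 40 mg/kg in this assay, at which 2 of the 3 values shown sit, holds the other two. Compound 2 `CCCCCCCc1nncn1-c1ccc(OCCCCCC)cc1` reaches only the limit of this assay, at > 40 mg/kg. Compound 3 `CCCCCCCCCc1nncn1-c1ccc(OCCCCCC)cc1` likewise reaches only that limit, at > 40 mg/kg. The two measured steps from compound 1 are therefore floors: an at least 1.2-fold higher number from compound 1 to compound 2 (0.08 log units; that floor lies within the scatter) and an at least 1.2-fold higher number from compound 1 to compound 3 (0.08 log units; that floor lies within the scatter), each from an alkyl group in place of hydrogen on a saturated chain carbon, and a step that the two limits leave unreadable from compound 2 to compound 3 cannot be read at all.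

Compound 4 `CCCCCCOc1ccc(-n2cnnc2-c2ccccc2Cl)cc1` departs from compound 1 in a different way: 2-chlorophenyl in place of pentyl on an aromatic carbon. Going by the values given here, no measured step touches this aromatic carbon, so none bears directly on it; the floors from compound 1 only show that adding to the chain does not lower the number. Compound 4 is expected to stay close to compound 1, without a step beyond the scatter in either direction. Compound 4 is thus estimated at 30 mg/kg, between 12 mg/kg and 75 mg/kg. That estimate amounts to a step of a 1.1-fold lower number from compound 1 to compound 4 (0.04 log units; within the scatter).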

Compound 4, dose for half-maximal effect: 13.2 mg/kg
Compound 4: middle estimate off by 2.3-fold (0.36 log units), on the high side; the range from low to high includes it.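

For the compounds shown here, at the aromatic carbon between two ring nitrogen atoms, 2-chlorophenyl in place of pentyl gives a 2.5-fold lower number from compound 1 to compound 4 (0.40 log units; beyond the scatter) in this assay, the first step that is beyond the scatter and the first that can be read as a drop in the number. The same group in place of nonyl gives an at least 3.0-fold lower number from compound 3 to compound 4 (0.48 log units; beyond the scatter) and in place of heptyl gives an at least 3.0-fold lower number from compound 2 to compound 4 (0.48 log units; beyond the scatter), but both of these sizes are floors rather than measured gaps: the limit of > 40 mg/kg in this assay, at which 2 of the 4 values shown sit. Among the four compounds shown, compound 4 therefore has the lowest number, and it alone carries a six-membered aromatic ring of carbon only at this position, so this carbon accepts a ring as well as a chain.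

With only one ring-bearing group here, the compounds shown do not separate the part played by the ring from that of the chlorine, which a plain phenyl or a 2-fluorophenyl group would address. They also leave open how a shorter chain such as propyl would read at this carbon, and whether the step holds if a butoxy group replaces the hexyloxy group on the other ring.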